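The compounds below may be only part of what the source reports. "The series", "measured", "known", "first", "only" and "open" are said of these compounds alone.

Measured so far:
Compound 1 `CC(C)CN(CC(=O)N(CC(C)C)NC(=O)OCc1ccccc1)NC(=O)CBr`: 6500 nM
Compound 2 `CC(C)CN(NC(=O)OCc1ccccc1)C(=O)CN(Cc1ccccc1)NC(=O)Cc1cccc(Br)c1`: 30000 nM
Compound 3 `CC(C)CN(CC(=O)N(Cc1ccccc1)NC(=O)OCc1ccccc1)/N=C/c1ccccc1B(O)O`: 18400 nM

All three values come from a functional assay on L1210 cells (Mus musculus) for inhibition; on this read-out higher numbers stand for weaker inhibition and lower numbers for stronger inhibition. On this scale, compound 2 at 30000 nM cannot be separated from compound 3 at 18400 nM, because the two numbers lie within the usual scatter. Compound 1 at 6500 nM has a clearly lower number than compound 2, a gap beyond the scatter, and so shows stronger inhibition.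

The next compound to be tested is compound 4 `CC(C)CN(NC(=O)OCc1ccccc1)C(=O)CN(Cc1ccccc1)/N=C/c1cccc(B(O)O)c1`. It keeps the rest of compound 2 but changes one group: a group of 11 heavy atoms (7 carbon, 1 boron, 1 nitrogen, 2 oxygen; one six-membered aromatic ring of carbon only) in place of a group of 11 heavy atoms (8 carbon, 1 nitrogen, 1 oxygen, 1 bromine; one six-membered aromatic ring of carbon only), on an amine nitrogen. The incoming group contains boron and no bromine, and it has more hydrogen-bond donors and acceptors than the group it replaces.

Among the measured compounds shown here, no measured pair of compounds differs in only one place, so the size of this change has not been observed directly. For the measured compounds named here, compound 3, the only measured compound containing boron, gives 18400 nM, which offers some guidance but differs from compound 4 in more than one place. A small move toward a lower number in this assay is therefore expected, with nothing beyond the scatter. The expected change is a 1.5-fold lower number from compound 2 to compound 4 (0.18 log units; within the scatter). For compound 4, the estimated value is 20000 nM, with an expected range from 8000 nM to 50000 nM.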

Compound 4, half-maximal inhibitory concentration: 16200 nM
Compound 4: the middle estimate sits 1.2-fold (0.09 log units) above what was measured; the range from low to high includes it.
By their numbers in this assay, from the lowest: compound 1; then compounds 4, 3 and 2 (each within the scatter of the next).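

In this assay, the exchange on this amine nitrogen gives a 1.9-fold lower number from compound 2 to compound 4 (0.27 log units; within the scatter), so the group containing boron and the group containing bromine cannot be told apart on this read-out. Among the compounds shown here, this is the first direct look at a single change at this position, and it shows that bromine can give way to boron, with more hydrogen-bond donors and acceptors in the incoming group, without a shift that stands clear of the scatter. Nothing available here bears on why the two groups of 11 heavy atoms read alike.

Still open, on these data alone, is whether any group on this amine nitrogen can move the number beyond the scatter, for instance one ending in a carboxylic acid or a simple amine, or a plain longer chain. Also open, as far as these compounds go, is how much the boron atom itself contributes, which could be tested by comparing compound 4 with a partner that has a carboxylic acid in place of the boron-bearing part and is otherwise the same.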